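This account rests on a few compounds, and the source may have more. Where it says the series, first, only, none or still open, it means among the compounds named here.

In a functional assay on MT4 cells (Homo sapiens) for cytotoxicity (on this read-out higher numbers stand for lower toxicity in this test and lower numbers for higher toxicity in this test), compound 1 `CC(c1ccccc1)c1cc(O)nc(SC2CCCCC2)n1` gives 149000 nM. Compound 2 `CCC(c1cc(O)nc(SC2CCCCC2)n1)c1c(F)cccc1F` reads > 200000 nM, which is a limit of the assay and not a number. Compound 3 `CC(c1cc(O)nc(SC2CCCCC2)n1)c1c(F)cccc1F` differs from compound 2 in one place: hydrogen in place of methyl on a saturated chain carbon, two bonds along the chain from two aromatic carbons. Among the compounds with values here, no measured pair shows this change, so no step beyond the usual scatter is expected in this assay, and compound 3 may also read as a limit. The expected change is an at least 1.1-fold lower number from compound 2 to compound 3 (0.04 log units; that floor lies within the scatter). Compound 3 is estimated at 180000 nM, with an expected range from 100000 nM to 260000 nM.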

Compound 3, half-maximal cytotoxic concentration: > 200000 nM
Compound 3: only a limit was reported; the forecaster's own chance of this, stated with the estimate: 50%; middle value at least 1.1-fold (0.04 log units) from the limit.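

In this assay, 2,6-difluorophenyl in place of phenyl on the saturated chain carbon gives an at least 1.3-fold higher number from compound 1 to compound 3 (0.12 log units; that floor lies within the scatter), so this change brings no lower number in this test. Compound 3 reads > 200000 nM, which is a limit of the assay and not a number. Compound 2 sits at the same limit, so the step from ethyl to methyl cannot be read: the limit of > 200000 nM in this assay, at which 2 of the 3 values shown sit.

From the compounds shown here alone, how far either compound lies past that limit stays open. So does whether an amine or a carboxylic acid on that chain carbon would give a readable number.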